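Swapping the nitrogen substituent in a cytotoxic sulfonamide series

This account rests on a few compounds, and the source may have more. Where it says the series, first, only, none or still open, it means among the compounds named here.

Of the compounds shown here, three sharing one core have been measured in a functional assay on Ehrlich cells (Mus musculus) for cytotoxicity, read by trypan blue exclusion, with a stated time of 2 h, tested at 10 ug/mL; a lower number here means a weaker effect, a higher number a stronger effect of the compound at the concentration tested. Compound 1 `N#CC1=C(N)N(c2ccc(S(N)(=O)=O)cc2)C2=C(C(=O)CCC2)C1c1ccc(Cl)cc1Cl` gives 40%. Compound 2 `CCCCNC(=S)NC1=C(C#N)C(c2ccc(Cl)cc2Cl)C2=C(CCCC2=O)N1c1ccc(S(N)(=O)=O)cc1` gives 30%. Compound 3 `C=CCNC(=S)NC1=C(C#N)C(c2ccc(Cl)cc2Cl)C2=C(CCCC2=O)N1c1ccc(S(N)(=O)=O)cc1` gives 10%. Among these, compound 2 stands second of the three; its gap to compound 1 is within the scatter, while a number 20 percentage points lower from compound 2 to compound 3 (beyond the scatter) is beyond it.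

Compound 4 `N#CC1=C(NS(=O)(=O)c2ccc([N+](=O)[O-])cc2)N(c2ccc(S(N)(=O)=O)cc2)C2=C(C(=O)CCC2)C1c1ccc(Cl)cc1Cl` is not yet measured. It differs from compound 2 in that (a group of 12 heavy atoms (6 carbon, 1 nitrogen, 4 oxygen, 1 sulfur; one six-membered aromatic ring of carbon only) in place of a group of 7 heavy atoms (5 carbon, 1 nitrogen, 1 sulfur; no ring), on an amine nitrogen). Going by the values given here, the steps that bear on this place are a number 10 percentage points lower from compound 1 to compound 2 (within the scatter) and a number 30 percentage points lower from compound 1 to compound 3 (beyond the scatter): both attached a group to the same amine nitrogen, and neither raised the number; one left it within the scatter and one lowered it modestly. Among the compounds with values here, no measured compound carries an aromatic group on that nitrogen, so the size of the step stays uncertain. Compound 4 is therefore expected to come out at 25%, between 5% and 45%. This estimate amounts to an expected step of a number 5 percentage points lower from compound 2 to compound 4 (within the scatter), a small decrease or no change beyond the scatter.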

Compound 4, a percentage reported as activity, at one concentration (the size of the read-out at that concentration, not a potency): 50%
Compound 4: the middle estimate sits 25 percentage points below what was measured; the measured number lies above the stated range.
By their numbers in this assay, from the lowest: compound 3; then compounds 2, 1 and 4 (each within the scatter of the next, the first and the last beyond it).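

Until now, each group placed on this amine nitrogen had left the number no higher than in compound 1, but in this assay the (4-nitrophenyl)sulfonyl group, with its aromatic ring, gives (a number 10 percentage points higher from compound 1 to compound 4 (within the scatter)), so this position can carry it with the read-out held level. Set against the two chains, the same group makes a clear difference (a number 20 percentage points higher from compound 2 to compound 4 (beyond the scatter); a number 40 percentage points higher from compound 3 to compound 4 (beyond the scatter)), so the choice of group here can move the number up as well as down. Nothing measured explains why this group behaves differently from the chains.

The compounds shown do not separate the contributions of the nitro group, the benzene ring and the sulfonyl link. A plain phenylsulfonyl or a methylsulfonyl group on the same nitrogen would help to tell these apart.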